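Removing a Methyl Group From the Pendant Phenyl Ring

The source may hold more compounds than are shown below. What is called first, only, known or untested is meant among the compounds shown, and "the series" means these compounds.

Compound 1, `COc1cc2c(Oc3ccc(NC(=O)c4nn(-c5ccccc5C)cc(C)c4=O)cc3)ccnc2cc1OCCCCCC(=O)NO`, gives 1830 nM in a functional assay on MCF7 cells (Homo sapiens) for inhibition, read by MTT assay, with a stated time of 72 h; a higher number here means a weaker inhibitor, a lower number a stronger inhibitor. Compound 2, `COc1cc2c(Oc3ccc(NC(=O)c4nn(-c5ccccc5C)ccc4=O)cc3)ccnc2cc1OCCCCCC(=O)NO`, gives 4360 nM. Compound 3, `COc1cc2c(Oc3ccc(NC(=O)c4nn(-c5ccccc5C)cc(C)c4=O)cc3F)ccnc2cc1OCCCC(=O)NO`, gives 2600 nM.

All three share a large core that ends in a hydroxamic acid chain, and they differ in small details. From compound 1 to compound 2 one methyl group is lost: hydrogen in place of methyl on an aromatic carbon. This produced a 2.4-fold higher number from compound 1 to compound 2 (0.38 log units; beyond the scatter), so the smaller compound is the weaker inhibitor. Compound 3 differs from compound 1 in more than one place, and the difference between the two cores is not broken down here; the values of compound 3 and compound 1 lie within the usual scatter of one another, so nothing can be said about their order.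

Compound 4, `COc1cc2c(Oc3ccc(NC(=O)c4nn(-c5ccccc5)cc(C)c4=O)cc3F)ccnc2cc1OCCCC(=O)NO`, has not yet been measured. It differs from compound 3 as follows: hydrogen in place of methyl on an aromatic carbon. This is the same kind of change as that from compound 1 to compound 2, but not the same change: there the methyl sat on an aromatic carbon of a six-membered aromatic ring with 2 nitrogen, meta to a 2-methylphenyl group and opposite the ring nitrogen, whereas here it sits on a six-membered aromatic ring of carbon only, ortho to a large group. A step of about a 1.5-fold higher number from compound 3 to compound 4 (0.19 log units; within the scatter) is expected from compound 3 to compound 4 in this assay, resting on the modest size of a 2.4-fold higher number from compound 1 to compound 2 (0.38 log units; beyond the scatter) and on the different surroundings, which make a smaller or similar effect plausible. Compound 4 is therefore estimated at 4000 nM, with a range from 1800 nM to 9000 nM.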

Compound 4, half-maximal inhibitory concentration: 1900 nM
Beside the measured number, compound 4's estimate is 2.1-fold (0.32 log units) above it, within the range that was stated.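

In this assay, replacing the methyl of the 2-methylphenyl group with hydrogen gives a 1.4-fold lower number from compound 3 to compound 4 (0.14 log units; within the scatter), so this pair cannot be placed in any order. The loss of a methyl from an aromatic carbon therefore did not behave alike in the two cases, and the step seen on the core of compound 1 cannot simply be carried over to the core of compound 3: the same change on two cores in this assay, a 2.4-fold higher number (0.38 log units; beyond the scatter) from compound 1 to compound 2 and a 1.4-fold lower number (0.14 log units; within the scatter) from compound 3 to compound 4, 3.3-fold (0.51 log units) apart, beyond the scatter of two such steps This shows that the earlier step is a poor guide here, but it does not show why, since the two pairs differ both in the surrounding core and in where the methyl sits, on a six-membered aromatic ring with 2 nitrogen in one pair and on a six-membered aromatic ring of carbon only in the other.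

The compounds shown leave open what each methyl does on a single core, for example what the step from 2-methylphenyl to phenyl gives on the core of compound 1. They also leave open whether an ethyl group or a chlorine atom in place of that methyl would give a value that differs from those of compound 3 and compound 4 by more than the scatter.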